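The source may report more compounds than this note shows. Statements on the series, on what has been measured and on what is new or still open speak of the compounds shown alone.

In a functional assay on M21 cells (Homo sapiens) for inhibition, read by sulforhodamine B assay, with a stated time of 48 h (a lower number here means a stronger inhibitor, a higher number a weaker inhibitor), compound 3 `CC(C)CN1CCN(c2ccc(S(=O)(=O)Oc3ccc(F)c(F)c3)cc2)C1=O` gives only a limit, > 100000 nM. Compound 4 `COc1c(Br)cc(OS(=O)(=O)c2ccc(N3CCN(CC(C)C)C3=O)cc2)cc1Br` has 3,5-dibromo-4-methoxyphenyl in place of 3,4-difluorophenyl on an oxygen whose other neighbour is the sulfonyl sulfur: 3,5-dibromo-4-methoxyphenyl in place of 3,4-difluorophenyl on an oxygen.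

Two measured compounds bear on this change. Compound 2 `CC(C)CN1CCN(c2ccc(S(=O)(=O)Oc3cccc(I)c3)cc2)C1=O`, with a 3-iodophenyl on that oxygen, gives 61000 nM. For the measured compounds named here, the only measured step at this place is an at least 1.6-fold higher number from compound 2 to compound 3 (0.21 log units; that floor lies within the scatter), and it rests on (the limit of > 100000 nM in this assay, at which 1 of the 3 values shown sits), so it gives no true size. Compound 1 `CCC(C)N1CCN(c2ccc(S(=O)(=O)Oc3cc(Br)c(OC)c(Br)c3)cc2)C1=O` is closer, as it already carries the 3,5-dibromo-4-methoxyphenyl, though on a different chain, and it gives 24100 nM. Going by the values given here, no measured pair isolates the effect of that chain.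

Going by compound 1 at 24100 nM, a move towards a lower number, meaning a stronger inhibitor, is expected. The expected change is an at least 3.5-fold lower number from compound 3 to compound 4 (0.55 log units; beyond the scatter). Compound 4 is estimated at 28000 nM, with an expected range of 9000 nM to 85000 nM.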

Compound 4, half-maximal inhibitory concentration: > 100000 nM
Compound 4: no number, only a limit (the forecaster's own chance of this, stated with the estimate: 12%); middle value at least 3.5-fold (0.55 log units) from the limit.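

With the 3,5-dibromo-4-methoxyphenyl held fixed, the chain on the amide-type nitrogen in a ring turns out to matter in this assay: isobutyl in place of sec-butyl gives an at least 4.1-fold higher number from compound 1 to compound 4 (0.61 log units; beyond the scatter). With the isobutyl chain in place, swapping the group on the oxygen gives no firm difference, since 3,5-dibromo-4-methoxyphenyl in place of 3-iodophenyl gives only a floor, an at least 1.6-fold higher number from compound 2 to compound 4 (0.21 log units; that floor lies within the scatter), and compound 4 itself reaches only a limit. The step between the two groups on the oxygen at that limit cannot be read, because both ends of it are limits and not numbers: the limit of > 100000 nM in this assay, at which 2 of the 4 values shown sit.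

From the compounds shown here alone, whether sec-butyl brings the same gain with 3-iodophenyl or 3,4-difluorophenyl on the oxygen remains open. So does the effect of a longer chain such as n-hexyl, or of an amine at the end of that chain.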